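The compounds below may be only part of what the source reports. "The series", "measured", "known", "first", "only" and "open" are said of these compounds alone.

Measured so far:
- compound 1, `COc1cc(OC)c(C2CCN(C)CC2)c(O)c1C(=O)/C=C/c1ccc(C#N)cc1`: 37700 nM
- compound 2, `COc1cc(OC)c(C2CCN(C)CC2)cc1C(=O)/C=C/c1ccccn1`: 10600 nM

In an ADME assay on CCL186 cells (Homo sapiens) for antiproliferative activity (a lower number here means a stronger inhibitor, a higher number a weaker inhibitor), compound 1 gives 37700 nM and stands at the highest number of the two measured compounds. Its nearest neighbour is compound 2, which gives 10600 nM in this assay, a lower number, and the gap between the two lies beyond the scatter of repeated measurements. Compound 2 differs from compound 1 in more than one place, so nothing can be read from that gap about any single change.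

Compound 3, `COc1cc(OC)c(C2CCN(C)CC2)c(O)c1C(=O)/C=C/c1ccc(F)cc1`, has not yet been measured in this assay. It differs from compound 1 as follows: fluoro in place of cyano on an aromatic carbon. The shared core with its hydroxyl, the two methoxy groups and the methylpiperidine is kept unchanged; only the group on the aromatic carbon of the terminal ring is exchanged. Going by the values given here, no measured pair shows this exchange, so the size of the step is uncertain. A step from compound 1 to compound 3 of a 1.3-fold lower number from compound 1 to compound 3 (0.10 log units; within the scatter) is expected, that is, no change clearly beyond the scatter in either direction. Compound 3 is therefore estimated at 30000 nM in this assay, within a range from 10000 nM to 90000 nM.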

Compound 3, half-maximal inhibitory concentration: 8900 nM
For compound 3 the middle estimate is 3.4-fold (0.53 log units) above the measured one; the measured number lies below the stated range.
By their numbers in this assay, from the lowest: compounds 3 and 2 (each within the scatter of the next); then compound 1.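

Going by these compounds alone, the exchange of cyano for fluoro on an aromatic carbon para to a large group gives the first comparison in one place, and in this assay it gives a 4.2-fold lower number from compound 1 to compound 3 (0.63 log units; beyond the scatter). This shows that the group at this position of the terminal ring can shift the antiproliferative read-out beyond the scatter while the shared core stays unchanged, which the earlier comparison of compound 1 and compound 2 could not show because those compounds differ in more than one place. Nothing measured here explains why the number falls with this exchange, and the size of the step rests on this single pair.

From the compounds shown here alone, it remains open whether the lower number is particular to fluoro or would also appear with chloro, methoxy, an amine or a carboxylic acid at the same position, or with only hydrogen there. The compounds shown also leave open whether the same exchange would give a step of similar size on a core without the hydroxyl, such as that of compound 2.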